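Adding a dimethoxyphenyl group to a chlorinated compound

A few compounds are considered here, and "the series" means these few. Any claim that something is new, unique, unknown or untested is made for them only; others in the source may bear on it.

Compound 1 `COc1ccc(N(C)c2ncnc3c2ncn3C)cc1`: > 100000 nM, a limit of the assay
Compound 2 `COc1ccc(N(C)c2nc(Cl)nc3c2ncn3C)cc1`: 2300 nM

Going by the values given here, in a functional assay on K562 cells (Homo sapiens) for antiproliferative activity, read by MTT assay, with a stated time of 48 h (a lower number here means a stronger inhibitor of growth, a higher number a weaker inhibitor of growth), compound 2 gives 2300 nM, the only true number so far. For compound 1 there is only (the limit of > 100000 nM in this assay, at which 1 of the 2 values shown sits). Compound 2 therefore cannot yet be ranked within a series of measured numbers.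

The next compound is compound 3 `COc1ccc(N(C)c2nc(Cl)nc3c2ncn3Cc2cc(OC)cc(OC)c2)cc1`. The structural change is 3,5-dimethoxyphenyl in place of hydrogen on a saturated chain carbon bound to an aromatic nitrogen. A 3,5-dimethoxyphenyl group thus replaces a hydrogen on a saturated chain carbon bound to an aromatic nitrogen.

Among the compounds with values here, the only measured step is an at least 43-fold lower number from compound 1 to compound 2 (1.63 log units; beyond the scatter). It was large, but it involved chloro in place of hydrogen on an aromatic carbon. It therefore gives only weak guidance, since no change at the saturated chain carbon has been measured. With no evidence favouring either direction, the best guess in this assay is no shift beyond the scatter, and the expected step is a 1.2-fold lower number from compound 2 to compound 3 (0.06 log units; within the scatter). Compound 3 is estimated at 2000 nM, with an expected range from 200 nM to 20000 nM.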

Compound 3, concentration for 50% growth inhibition: 42000 nM
For compound 3 the middle estimate is 21-fold (1.32 log units) below the measured one, outside the stated range (above it).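

Going by these compounds alone, this is the first measured change at the saturated chain carbon bound to an aromatic nitrogen, and in this assay it gives an 18-fold higher number from compound 2 to compound 3 (1.26 log units; beyond the scatter). Since a higher number here means weaker inhibition of growth, this carbon is not a place where any group can be added freely: the 3,5-dimethoxyphenyl group, with its six-membered aromatic ring and two oxygen atoms, costs much of the activity of compound 2, even though compound 3 keeps the same chloro group, so that group alone does not secure the stronger value. The data shown do not explain why this added group weakens the growth inhibition.

On these data alone, it remains open whether the loss comes from the aromatic ring itself or from its two methoxy groups, and a plain phenyl ring at the same carbon would help to separate the two. Also open, as far as these compounds go, is how a longer saturated chain or an amine would behave at this carbon, and whether any group placed here could give a lower number than compound 2 does.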